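The source may hold more compounds than are shown below. What is called first, only, known or untested is meant among the compounds shown, and "the series" means these compounds.

In a functional assay on MCF7 cells (Homo sapiens) for antiproliferative activity, read by MTT assay, with a stated time of 24 h (a higher number here means a weaker inhibitor, a lower number a stronger inhibitor), compound 1 `COC(=O)c1scc(-c2ccc(NC(=O)c3ccc4ccccc4c3)cc2)c1OC` gives 90 nM and compound 2 `COC(=O)c1scc(-c2ccc(NC(=O)c3cccc(C(F)(F)F)c3)cc2)c1OC` gives 26200 nM. Compound 3 `COC(=O)c1scc(-c2ccc(NC(=O)c3cccc(I)c3)cc2)c1OC`, at 12300 nM, has the second highest of the three numbers. Compound 4 `COC(=O)c1scc(-c2ccc(NC(=O)c3cccc(OC(F)(F)F)c3)cc2)c1OC` makes one change to it: trifluoromethoxy in place of iodo on an aromatic carbon. Within the data shown here, the nearest precedent is the swap of trifluoromethyl for iodo at that place, a 2.1-fold lower number from compound 2 to compound 3 (0.33 log units; beyond the scatter), a modest step. The large steps, a 290-fold higher number from compound 1 to compound 2 (2.46 log units; beyond the scatter) and a 140-fold higher number from compound 1 to compound 3 (2.14 log units; beyond the scatter), both involve loss of naphthalen-2-yl, which compound 4 also lacks, so they do not bear directly on this change. In this assay, a small upward shift or none beyond the scatter is therefore expected, and the estimated step is a 1.3-fold higher number from compound 3 to compound 4 (0.11 log units; within the scatter). For compound 4 the expected value is 16000 nM, within an estimated range of 6000 nM to 40000 nM.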

Compound 4, half-maximal inhibitory concentration: 2220 nM
The estimate for compound 4 lay 7.2-fold (0.86 log units) above the measured number; measured number below the stated range.
By their numbers in this assay, from the lowest: compound 1; then compound 4; then compound 3; then compound 2.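

In this assay, the aromatic carbon meta to a large group responds more strongly than the earlier trifluoromethyl and iodo pair showed: trifluoromethoxy gives a 5.5-fold lower number from compound 3 to compound 4 (0.74 log units; beyond the scatter) and a 12-fold lower number from compound 2 to compound 4 (1.07 log units; beyond the scatter) as the two steps. Among the three compounds without naphthalen-2-yl, the choice of this one substituent therefore spans a large range. Nothing measured bears on the cause of these steps. Open, on these data alone, is whether the oxygen link or the fluorines drive the change, which methoxy at the same carbon would test.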